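Compound 3 to compound 4: piperazin-1-yl enters

The compounds below may be only part of what the source reports. "The series", "measured", "known", "first", "only" and "open" are said of these compounds alone.

Measured so far in a functional assay on RKOp27 cells (Homo sapiens) for cytotoxicity, read by MTT assay, with a stated time of 3 days; on this read-out lower numbers stand for stronger inhibition and higher numbers for weaker inhibition
Compound 1 `CCNc1nc(SCc2nc3ccccc3[nH]2)nc(-c2ccccc2)c1C#N` gives 7.35 nM
Compound 2 `N#Cc1c(Nc2ccccn2)nc(SCc2nc3ccccc3[nH]2)nc1-c1ccccc1` gives 3.8 nM
Compound 3 `N#Cc1c(NC(N)=S)nc(SCc2nc3ccccc3[nH]2)nc1-c1ccccc1` gives 2.63 nM

Of the three, compound 3 (2.63 nM) has the lowest number, but only compound 1 is clearly separated from it: a 2.8-fold lower number from compound 1 to compound 3 (0.45 log units; beyond the scatter). Compound 2 cannot be told apart from it: a 1.4-fold lower number from compound 2 to compound 3 (0.16 log units; within the scatter).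

The next compound, compound 4 `N#Cc1c(-c2ccccc2)nc(SCc2nc3ccccc3[nH]2)nc1N1CCNCC1`, changes the same spot on the shared core, an aromatic carbon next to the ring nitrogen and ortho to a cyano group: a group of 6 heavy atoms (4 carbon, 2 nitrogen; one six-membered non-aromatic ring with 2 hetero atoms) in place of a group of 4 heavy atoms (1 carbon, 2 nitrogen, 1 sulfur; no ring), on an aromatic carbon.

The three measured steps all change what sits on the nitrogen at this spot. The third is a 1.9-fold lower number from compound 1 to compound 2 (0.29 log units; within the scatter). All of them are small, so this spot has tolerated quite different groups so far. None of the three compounds carries a ring of the new kind, however, so the data give only indirect guidance. Compound 3 lies at the low end of the series, so a small move towards a higher number in this assay seems more likely than a further fall. The expected change is a 2.3-fold higher number from compound 3 to compound 4 (0.36 log units; beyond the scatter). The estimate for compound 4 is 6 nM, with an expected range from 2 nM to 25 nM.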

Compound 4, half-maximal inhibitory concentration: 5.81 nM
For compound 4 the middle estimate is 1.0-fold (0.01 log units) above the measured one, within the range that was stated.
By their numbers in this assay, from the lowest: compounds 3, 2, 4 and 1 (each within the scatter of the next, the first and the last beyond it).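

Piperazin-1-yl is the first group in this set to place a six-membered non-aromatic ring on this aromatic carbon, and in this assay its exchange for the open-chain group gives a 2.2-fold higher number from compound 3 to compound 4 (0.34 log units; beyond the scatter), a modest but real rise. Against the two amino groups, the same ring gives a 1.5-fold higher number from compound 2 to compound 4 (0.18 log units; within the scatter) and a 1.3-fold lower number from compound 1 to compound 4 (0.10 log units; within the scatter), so it cannot be told apart from (pyridin-2-yl)amino or ethylamino, and the position accepts this ring with only the comparison to compound 3 showing any cost. Nothing available here accounts for that difference from compound 3.

Going by these compounds, it remains open whether the second nitrogen of the ring matters: morpholin-4-yl or piperidin-1-yl at this spot would put an oxygen or a carbon in its place. Also unresolved is how the free hydrogen on that nitrogen figures in the result, which 4-methylpiperazin-1-yl would address, and whether a longer chain such as butylamino would behave like the ethylamino group or like the ring.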